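The source may report more compounds than this note shows. Statements on the series, on what has been measured and on what is new or still open speak of the compounds shown alone.

Measured compounds:
- compound 1 `CCc1ccc(Cn2c(CCc3ccccc3)nnc2[C@H](NC(=O)c2ccncc2)c2c[nH]c3ccccc23)cc1`: > 1000 nM in an in vitro assay on LLC-PK1 cells for displacement of a labelled ligand from growth hormone secretagogue receptor type 1 (Homo sapiens) (on this read-out lower numbers stand for stronger inhibition and higher numbers for weaker inhibition), which is a limit of the assay rather than a number
- compound 2 `COc1ccc(Cn2c(CCc3ccccc3)nnc2[C@H](NC(=O)c2cnccn2)c2c[nH]c3ccccc23)c(OC)c1`: 5 nM in this assay

Among the compounds with values here, compound 2 stands as the only actual number in this assay; the other value shown is a limit. Compound 1 sits at the limit of > 1000 nM in this assay, at which 1 of the 2 values shown sits, so nothing beyond that is known about it.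

Compound 3 `CCc1ccc(Cn2c(CCc3ccccc3)nnc2[C@H](NC(=O)c2cnccn2)c2c[nH]c3ccccc23)cc1` is the next compound to be measured. It differs from compound 2 by 4-ethylphenyl in place of 2,4-dimethoxyphenyl on a saturated chain carbon bound to an aromatic nitrogen, that is, 2,4-dimethoxybenzyl becomes 4-ethylbenzyl. Within the data shown here, no pair of measured compounds differs in only this one place, so the size of this step has not been seen directly; compound 1 carries the same 4-ethylbenzyl group as compound 3 but differs from compound 2 in a second place as well, and its value is only a limit.

The step from compound 2 to compound 3 is expected to weaken binding beyond the usual scatter, a 12-fold higher number from compound 2 to compound 3 (1.08 log units; beyond the scatter). Compound 3 is estimated at 60 nM, with a likely range from 6 nM to 800 nM.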

Compound 3, half-maximal inhibitory concentration: 89 nM
Beside the measured number, compound 3's estimate is 1.5-fold (0.17 log units) below it, and the stated range covers the measured number.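

In this assay, the change from 2,4-dimethoxybenzyl to 4-ethylbenzyl can now be read directly, and it matters: an 18-fold higher number from compound 2 to compound 3 (1.25 log units; beyond the scatter). With 4-ethylbenzyl held constant, the group on the carbonyl carbon also matters, as pyrazin-2-yl in place of pyridin-4-yl gives an at least 11-fold lower number from compound 1 to compound 3 (1.05 log units; beyond the scatter), so changing either place alone shifts the read-out beyond the scatter. That second step gives only a minimum size, because the value for compound 1 is a limit of the assay and not a number: the limit of > 1000 nM in this assay, at which 1 of the 3 values shown sits.

The single change in compound 3 replaces the whole 2,4-dimethoxyphenyl group, so the compounds shown cannot say which part of that group accounts for the step. From the compounds shown here alone, it remains open whether a plain benzyl or a 4-methoxybenzyl group would land nearer compound 2 or compound 3.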